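A few compounds are considered here, and "the series" means these few. Any claim that something is new, unique, unknown or untested is made for them only; others in the source may bear on it.

Compound 2 `CN1CCN(c2ccc(Nc3ncc(Cl)c(NCc4ccco4)n3)nc2)CC1` was examined in a functional assay on MDA-MB-231 cells (Homo sapiens) for inhibition, read by CCK-8 assay, with a stated time of 48 h (a higher number here means a weaker inhibitor of growth, a lower number a stronger inhibitor of growth), where compound 2 gives 11000 nM. Compound 1 `COc1ccc(CNc2nc(Nc3ccc(N4CCN(C)CC4)cn3)ncc2Cl)cc1` gives 14900 nM in this assay, and the two numbers lie within the scatter of each other, as the step of a 1.4-fold lower number from compound 1 to compound 2 (0.13 log units; within the scatter) shows. Compound 3 `COc1ccc(Nc2nc(Nc3ccc(N4CCN(C)CC4)cn3)ncc2Cl)cc1` differs from compound 2 by 4-methoxyphenyl in place of (furan-2-yl)methyl on a nitrogen on an aromatic ring. Going by the values given here, the single measured step swapped the same two ring groups, but on a saturated chain carbon, and stayed within the scatter, so for compound 3 no shift beyond the scatter in this assay is expected. Compound 3 is estimated at 12000 nM, range 4000 nM to 36000 nM, an expected step of a 1.1-fold higher number from compound 2 to compound 3 (0.04 log units; within the scatter).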

Compound 3, concentration for 50% growth inhibition: 8020 nM
Estimate against measurement, compound 3: 1.5-fold (0.18 log units) above, within the range that was stated.
By their numbers in this assay, from the lowest: compounds 3, 2 and 1 (each within the scatter of the next).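

In this assay, the nitrogen on the aromatic ring takes 4-methoxyphenyl directly without a shift beyond the scatter: the change gives a 1.4-fold lower number from compound 2 to compound 3 (0.14 log units; within the scatter), and removing the saturated chain carbon of 4-methoxybenzyl gives a 1.9-fold lower number from compound 1 to compound 3 (0.27 log units; within the scatter). Thus, neither the change of ring nor the loss of that carbon moves the number beyond the scatter at this position. Nothing available explains this flat response. Going by these compounds, whether a longer chain, a cyclohexyl group or a phenyl ring carrying a carboxylic acid would move the number beyond the scatter remains open.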